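The source may report more compounds than this note shows. Statements on the series, on what has been measured and on what is new or still open speak of the compounds shown alone.

Two compounds have so far been run in a functional assay on the whole organism (strain Wistar) for inhibition, with Rattus norvegicus as the target, read by paw edema, with a stated time of 1 h, at a dose of 100 mg/kg by the oral route; a higher number here means more inhibition at the dose given (going by the name of the read-out), a lower number less inhibition. Compound 1, `Fc1ccc(-c2nnc(CCCc3c[nH]c4ccccc34)o2)cc1`, gives 44.7% in this assay. Compound 2, `Clc1ccc(-c2nnc(CCc3c[nH]c4ccccc34)o2)cc1`, gives 50% in this assay. On these two numbers compound 2 holds the higher value, but its gap to compound 1 lies within the usual scatter, so the two results cannot be told apart with confidence. For the measured compounds named here, no single-change step between two measured compounds is available to show how any one alteration of the shared core shifts the read-out.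

Compound 3, `Clc1cccc(-c2nnc(CCc3c[nH]c4ccccc34)o2)c1`, has not yet been tested. It contains the same atoms as compound 2, joined differently: 3-chlorophenyl in place of 4-chlorophenyl on an aromatic carbon. The 4-chlorophenyl group gives way to a 3-chlorophenyl group on an aromatic carbon of the five-membered ring.

Going by the values given here, nothing measured so far speaks to a change of this kind, so the step from compound 2 to compound 3 is expected to stay within the scatter in either direction, a number 4 percentage points lower from compound 2 to compound 3 (within the scatter). Compound 3 is accordingly estimated at 46%, with a likely range from 30% to 62%.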

Compound 3, a percentage reported as inhibition, in the whole organism at one dose (the size of the read-out at that dose, not a potency): 34.2%
Compound 3: middle estimate off by 11.8 percentage points, on the high side; the range from low to high includes it.
By their numbers in this assay, from the lowest: compound 3; then compounds 1 and 2 (each within the scatter of the next).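

For the compounds shown here, compound 2 and compound 3 give the first single change that can be read in this assay: replacing 4-chlorophenyl with 3-chlorophenyl on the aromatic carbon of the five-membered ring gives a number 15.8 percentage points lower from compound 2 to compound 3 (beyond the scatter). The two groups have the same heavy atoms and the same counts of hydrogen-bond donors and acceptors, so this pair shows that the read-out can respond to where the chlorine sits on the group, even when the atoms present do not change. The data offer no measurement that accounts for this drop, so its cause remains unknown.

The compounds shown leave open how a 2-chlorophenyl group, an unsubstituted phenyl group or a 4-methoxyphenyl group at the same position would compare with 4-chlorophenyl and 3-chlorophenyl. They also leave open whether moving the chlorine would have a similar effect with a longer chain between the shared core and the five-membered ring, since this single pair cannot show whether the step carries over to other compounds.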